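Ring contraction at the saturated ring carbon: cytotoxicity notes

The source may hold more compounds than are shown below. What is called first, only, known or untested is meant among the compounds shown, and "the series" means these compounds.

Compound 1 `Cc1cc(C)c(S(=O)(=O)N2CCC(C3OCC(C)CO3)CC2)c(C)c1`: > 5000 nM
Compound 2 `Cc1cc(C)c(S(=O)(=O)N2CCC(N3CCCCCC3)CC2)c(C)c1`: > 5000 nM

In an ADME assay on HCT-116 cells (Homo sapiens) for cytotoxicity, read by CellTiter-Glo, with a stated time of 72 h (on this read-out higher numbers stand for weaker inhibition and lower numbers for stronger inhibition), the value of compound 1 is a limit of the assay, not a number. The value of compound 2 is likewise a limit. The step that the two limits leave unreadable from compound 1 to compound 2 is therefore not readable, and compound 2 stands at the limit of > 5000 nM in this assay, at which 2 of the 2 values shown sit, as does every value shown.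

Compound 3 `Cc1cc(C)c(S(=O)(=O)N2CCC(N3CCCCC3)CC2)c(C)c1` differs from compound 2 by piperidin-1-yl in place of azepan-1-yl on a saturated ring carbon. For the measured compounds named here, no measured step bears on this change, so no shift beyond the scatter is expected: the step that the limit leaves unreadable from compound 2 to compound 3 is an estimate only. Compound 3 is expected at 10000 nM, within 4000 nM to 30000 nM, most likely again reported as a limit.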

Compound 3, half-maximal inhibitory concentration: > 5000 nM
Compound 3: only a limit was reported; the forecaster's own chance of this, stated with the estimate: 85%; the middle value is on the limit's open side.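

In this assay compound 3 gives > 5000 nM, a limit and not a number, so its steps from compound 1 and compound 2 cannot be read: the limit of > 5000 nM in this assay, at which 3 of the 3 values shown sit.

The compounds shown leave open whether any change on the saturated ring carbon shifts the read-out.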